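From 2-fluorophenyl to 4-fluorophenyl: a shift under a limit

The source may report more compounds than this note shows. Statements on the series, on what has been measured and on what is new or still open speak of the compounds shown alone.

Compound 1 `O=C(/C=C/c1cccc(F)c1)Nc1ccc(CC2=CC(=O)OC2)cc1`: 39000 nM
Compound 2 `O=C(/C=C/c1ccccc1F)Nc1ccc(CC2=CC(=O)OC2)cc1`: > 50000 nM
Compound 3 `C=C1OC(=O)C=C1Cc1ccc(NC(=O)/C=C/c2ccccc2F)cc1`: 13800 nM

In a functional assay on MCF7 cells (Homo sapiens) for cytotoxicity, read by MTT assay, with a stated time of 48 h (on this read-out lower numbers stand for stronger inhibition and higher numbers for weaker inhibition), compound 2 gives > 50000 nM, which is a limit and not a number. Compound 2 therefore stands at the limit of > 50000 nM in this assay, at which 1 of the 3 values shown sits.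

Compound 4 `O=C(/C=C/c1ccc(F)cc1)Nc1ccc(CC2=CC(=O)OC2)cc1` has not yet been measured. It has the same atoms as compound 2, joined differently: 4-fluorophenyl in place of 2-fluorophenyl on a double-bonded chain carbon bound to a double-bonded chain carbon.

Going by the values given here, two measured steps bear on this change. The closer one is a swap at the same place, an at least 1.2-fold higher number from compound 1 to compound 2 (0.10 log units; that floor lies within the scatter). Among the compounds with values here, its true size is hidden by the limit, so it shows only that a fluorine swap here need not do much. Compound 1, the 3-fluorophenyl member, gives 39000 nM and is the best numerical guide. The other step, an at least 3.6-fold lower number from compound 2 to compound 3 (0.55 log units; beyond the scatter), is larger, but it lies at a different place, on a saturated chain carbon bound to an aromatic carbon, so it says little here. Compound 3 gives 13800 nM.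

In this assay, no step beyond the scatter is expected, although the limit on compound 2 makes a lower number the likelier direction. The expected step is an at least 1.3-fold lower number from compound 2 to compound 4 (0.11 log units; that floor lies within the scatter). Compound 4 is estimated at 38000 nM, with an expected range of 15000 nM to 60000 nM.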

Compound 4, half-maximal inhibitory concentration: 47900 nM
Beside the measured number, compound 4's estimate is 1.3-fold (0.10 log units) below it; measured number inside the range.
By their numbers in this assay, from the lowest: compound 3; then compounds 1 and 4 (each within the scatter of the next). At a limit, above all of these: compound 2.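

In this assay, going by these compounds alone, this result gives the first comparison at this position with a number at both ends, and moving the fluorine from the 3-fluorophenyl to the 4-fluorophenyl member stays within the scatter (a 1.2-fold higher number from compound 1 to compound 4 (0.09 log units; within the scatter)), so this assay does not separate these two placements of the fluorine on the phenyl ring. Compound 2 remains a limit and not a number: the limit of > 50000 nM in this assay, at which 1 of the 4 values shown sits. The swap from the 2-fluorophenyl to the 4-fluorophenyl member can be read only as a floor (an at least 1.0-fold lower number from compound 2 to compound 4 (0.01 log units; that floor lies within the scatter)), and that floor lies within the scatter, so the true size of this step stays hidden and the 2-fluorophenyl member cannot yet be placed against the other two.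

On these data alone, all the groups compared at this position are fluorophenyl groups, so it remains open whether a methoxy group or an amine in place of the fluorine would move the number beyond the scatter. Also open, as far as these compounds go, is whether the change in the five-membered ring that separates compound 3 from compound 2 would give a similar step when carried onto the 4-fluorophenyl member.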